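Replacing the 2-methoxyphenyl group of compound 3

The compounds below may be only part of what the source reports. "The series", "measured", "known", "first", "only" and "open" are said of these compounds alone.

Of the compounds shown here, three have been measured in a functional assay on OVCAR-5 cells (Homo sapiens) for inhibition, with a stated time of 48 h, tested at 50 uM; on this read-out higher numbers stand for more inhibition of growth at the one concentration tested and lower numbers for less inhibition of growth. Compound 1 `CC[C@](C)(CCCC(C)C)CCc1ccc(O)c(I)c1` gives 11%, compound 2 `C=C[C@@](C)(/C=C/c1ccc(O)cc1)CC/C=C(/C)C=O` gives 22% and compound 3 `COc1ccccc1/C=C/[C@@](C)(/C=C/c1ccc(O)cc1)CCC=C(C)C` gives 38%. Compound 3 stands highest of the three, and its gaps to the other two both lie beyond the scatter. Within the data shown here, no two measured compounds differ in one place only, so the data do not show the size of any single change.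

The next compound is compound 4 `CC(C)=CCC[C@](C)(/C=C/c1ccc(O)cc1)/C=C/c1ccc(F)cc1`. The change is 4-fluorophenyl in place of 2-methoxyphenyl on a double-bonded chain carbon bound to a double-bonded chain carbon. Among the measured compounds shown here, the expectation rests on compound 3 at 38%, the only measured compound that carries a second aryl group. No step beyond the scatter is expected in this assay, with a slight fall as the likelier direction. The estimated change is a number 4 percentage points lower from compound 3 to compound 4 (within the scatter). For compound 4 the estimated value is 34%, with an expected range of 20% to 50%.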

Compound 4, percent growth inhibition at one concentration: 29%
Compound 4: middle estimate off by 5 percentage points, on the high side; the range from low to high includes it.
By their numbers in this assay, from the lowest: compound 1; then compounds 2, 4 and 3 (each within the scatter of the next, the first and the last beyond it).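

In this assay, among these compounds, 4-fluorophenyl in place of 2-methoxyphenyl on a double-bonded chain carbon bound to a double-bonded chain carbon gives a number 9 percentage points lower from compound 3 to compound 4 (within the scatter), the first single-place step. At this position, one aryl group can therefore replace another, with a different substituent and without the one hydrogen-bond acceptor counted in the leaving group, and no step beyond the scatter follows. Nothing measured here bears on the reason for this step.

The step changes the substituent and its ring position together, so 4-methoxyphenyl or 2-fluorophenyl at this place would be needed to separate the two. As far as these compounds go, whether this position needs an aryl group at all remains open, and a cyclohexyl group or a phenyl ring carrying an amine or a carboxylic acid would test how far the change can go.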